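The source may hold more compounds than are shown below. What is called first, only, known or untested is meant among the compounds shown, and "the series" means these compounds.

In a functional assay on PC-9 cells (Homo sapiens) for inhibition, read by MTT assay, with a stated time of 48 h, tested at 10 uM (a higher number here means more inhibition at the concentration tested (going by the name of the read-out), a lower number less inhibition), three compounds have been measured:
compound 1, `COc1cc(NC(=O)Nc2cc(Nc3ccc(OC)c(C)c3)ncn2)cc(OC)c1`, gives 62%;
compound 2, `CCc1cccc(Nc2cc(NC(=O)Nc3cc(OC)cc(OC)c3)ncn2)c1`, gives 82.1%;
compound 3, `COc1cc(NC(=O)Nc2cc(Nc3ccc(OC)c(I)c3)ncn2)cc(OC)c1`, gives 47.1%.

Compound 1 stands second of the three. Compound 2 lies above it, with a number 20.1 percentage points higher from compound 1 to compound 2 (beyond the scatter), and compound 3 lies below it, with a number 14.9 percentage points lower from compound 1 to compound 3 (beyond the scatter). Between the two ends the gap is a number 35 percentage points lower from compound 2 to compound 3 (beyond the scatter). Among the measured compounds shown here, all three share the same core, and every measured step exchanges one group for another on the nitrogen on an aromatic ring, so each of those steps changed only that one group.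

Compound 4, `COc1ccc(Nc2cc(NC(=O)Nc3c(Cl)cccc3Cl)ncn2)cc1C`, alters a different part of compound 1: 2,6-dichlorophenyl in place of 3,5-dimethoxyphenyl on an amide-type nitrogen. For the measured compounds named here, none of the measured steps touches this amide-type nitrogen, so none of them bears directly on the change. What they do show is that exchanging one aromatic group for another moves the read-out in this assay by modest to large amounts, in both directions. Without a guide at this position, the expected step is a number 12 percentage points lower from compound 1 to compound 4 (beyond the scatter), and the uncertainty around it is wide. For compound 4 the estimate is 50%, with a range from 20% to 80%.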

Compound 4, a percentage reported as inhibition, at one concentration (the size of the read-out at that concentration, not a potency): 80.1%
The estimate for compound 4 lay 30.1 percentage points below the measured number; the whole stated range lies below it.
By their numbers in this assay, from the lowest: compound 3; then compound 1; then compounds 4 and 2 (each within the scatter of the next).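

Among the compounds shown here, compound 4 gives the first reading at the amide-type nitrogen: in this assay, placing 2,6-dichlorophenyl there in place of 3,5-dimethoxyphenyl gives a number 18.1 percentage points higher from compound 1 to compound 4 (beyond the scatter). The read-out therefore responds to this side of the molecule as well as to the group on the other nitrogen, where the exchange for 3-ethylphenyl gave a number 20.1 percentage points higher from compound 1 to compound 2 (beyond the scatter). The two methoxy groups of compound 1 are also not required for inhibition at this concentration, since compound 4 lacks them and still gives 80.1%, but nothing shown explains why this exchange raises the number.

This single step removes the methoxy groups and adds the chlorines together, so it cannot say whether the loss, the gain or both account for the rise; a plain phenyl or a phenyl carrying a single chlorine at this nitrogen would begin to separate them. On these data alone, it also remains open whether 2,6-dichlorophenyl and 3-ethylphenyl, each tied to a higher number on its own, would add up when carried together on the shared core.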